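A few compounds are considered here, and "the series" means these few. Any claim that something is new, unique, unknown or untested is made for them only; others in the source may bear on it.

Compound 1 `CC(c1ccc(-c2ccccc2)c(F)c1)c1nnc2n1N=C(c1ccc(OC(F)(F)F)cc1)CS2`: 5400 nM
Compound 2 `COc1ccc2cc(C(C)c3n[nH]c(=S)n3N)ccc2c1`: 20200 nM

In a functional assay on HCT-116 cells (Homo sapiens) for inhibition, read by sulforhodamine B assay, with a stated time of 72 h (a higher number here means a weaker inhibitor, a lower number a stronger inhibitor), compound 1 holds the lower of the two numbers shown; compound 2 sits at a higher number, beyond the scatter. Compound 3 `CC(c1ccc(-c2ccccc2)c(F)c1)c1nnc2n1N=C(c1ccc([N+](=O)[O-])cc1)CS2` is not yet measured and differs from compound 1 in one place: nitro in place of trifluoromethoxy on an aromatic carbon. Among the measured compounds shown here, no measured pair shows this change, so the expectation rests on compound 1 alone. In this assay a small step is expected, a 1.4-fold lower number from compound 1 to compound 3 (0.13 log units; within the scatter), toward a lower number but not clearly beyond the scatter. Compound 3 is expected to give 4000 nM, within 1500 nM to 12000 nM.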

Compound 3, half-maximal inhibitory concentration: 7100 nM
For compound 3 the middle estimate is 1.8-fold (0.25 log units) below the measured one, and the stated range covers the measured number.
By their numbers in this assay, from the lowest: compounds 1 and 3 (each within the scatter of the next); then compound 2.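

In this assay, among the compounds shown here, the exchange gives a 1.3-fold higher number from compound 1 to compound 3 (0.12 log units; within the scatter) and is the first one-place comparison. At this position on the aromatic ring, para to a large group, 4-(trifluoromethoxy)phenyl and 4-nitrophenyl therefore cannot be told apart, although the two groups differ in heavy atoms and hydrogen-bond acceptors. Nothing available explains this result.

From the compounds shown here alone, what an amine or a carboxylic acid would give at this position stays open. Also open, going by these compounds, is whether the same reading holds when another part of compound 1 changes.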